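The compounds below may be only part of what the source reports. "The series", "measured", "known", "first", "only" and "open" are said of these compounds alone.

Measured in a physicochemical assay for solubility, at pH 7.4; a lower number here means a less soluble compound, a higher number a more soluble compound:
compound 1 `O=C(c1cccnc1)N1CCC(NS(=O)(=O)c2cc(S(=O)(=O)c3ccccc3)ccc2C(F)(F)F)CC1`: 78000 nM
compound 2 `O=C(O)c1cccc(S(=O)(=O)N2CCC(NS(=O)(=O)c3cc(S(=O)(=O)c4ccccc4)ccc3C(F)(F)F)CC2)c1`: > 100000 nM
compound 3 `O=C(C1CCNCC1)N1CCC(NS(=O)(=O)c2cc(S(=O)(=O)c3ccccc3)ccc2C(F)(F)F)CC1`: > 100000 nM

Compound 2 gives > 100000 nM, which is a limit of the assay and not a number. It is not alone there: the set shows (the limit of > 100000 nM in this assay, at which 2 of the 3 values shown sit).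

The next compound to consider is compound 4 `O=C([C@@H]1CCNC1)N1CCC(NS(=O)(=O)c2cc(S(=O)(=O)c3ccccc3)ccc2C(F)(F)F)CC1`, and the change that leads to it is (pyrrolidin-3-yl)carbonyl in place of (3-carboxyphenyl)sulfonyl on an amine nitrogen in a ring. In words, (pyrrolidin-3-yl)carbonyl stands in place of (3-carboxyphenyl)sulfonyl on an amine nitrogen in a ring.

The nearest measured comparison is a step that the two limits leave unreadable from compound 2 to compound 3, where (piperidin-4-yl)carbonyl enters in place of the same group. The other two steps, an at least 1.2-fold higher number from compound 1 to compound 2 (0.10 log units; that floor lies within the scatter) and an at least 1.2-fold higher number from compound 1 to compound 3 (0.10 log units; that floor lies within the scatter), offer only floors and no true sizes.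

Compound 3, the one carrying (piperidin-4-yl)carbonyl, gives > 100000 nM, again a limit of the assay, so compound 3 supports an expectation of no step beyond the scatter in this assay, in either direction, and quite possibly another limit. The step expected here is a number no higher from compound 2 to compound 4 (the limit leaves the size open). For compound 4 the estimated value is 100000 nM, with an expected range from 65000 nM to 150000 nM.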

Compound 4, solubility: 70000 nM
The estimate for compound 4 lay 1.4-fold (0.15 log units) above the measured number, and the stated range covers the measured number.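

In this assay, among the compounds shown here, compound 4 gives 70000 nM, the first true number for a non-aromatic ring on this carbonyl carbon. Setting pyrrolidin-3-yl in place of pyridin-3-yl gives a 1.1-fold lower number from compound 1 to compound 4 (0.05 log units; within the scatter), so on this ring nitrogen the two groups cannot be told apart in this assay. Against its other two neighbours, the result is an at least 1.4-fold lower number from compound 2 to compound 4 (0.15 log units; that floor lies within the scatter) and an at least 1.4-fold lower number from compound 3 to compound 4 (0.15 log units; that floor lies within the scatter), so neither the exchange of (3-carboxyphenyl)sulfonyl nor the exchange of piperidin-4-yl is shown to go beyond the scatter, and both steps are floors rather than true sizes, with two of the values being limits of the assay and not numbers: the limit of > 100000 nM in this assay, at which 2 of the 4 values shown sit.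

As far as these compounds go, how far compound 2 and compound 3 truly lie from compound 4 stays open, and a real size for either step would need values that fall inside the range of the assay. Also open, from the compounds shown here alone, is how the mirror-image form of pyrrolidin-3-yl would behave at this ring nitrogen, or a group with no ring at all, such as a plain acetyl or an open aminoalkyl chain on the same carbonyl.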